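Cyclobutyl for 4-methylphenyl: a cytotoxicity step in Vero cells

A few compounds are considered here, and "the series" means these few. Any claim that something is new, unique, unknown or untested is made for them only; others in the source may bear on it.

Compound 1 `CC1COC2(CCN(c3nc(=O)c4cc(C(F)(F)F)cc([N+](=O)[O-])c4s3)CC2)O1` gives > 125000 nM in an ADME assay on Vero cells (Chlorocebus sabaeus) for cytotoxicity, read by MTT assay, with a stated time of 72 h (on this read-out lower numbers stand for higher toxicity in this test and higher numbers for lower toxicity in this test), which is a limit of the assay.
Compound 2 `O=C(c1ccccc1F)N1CCN(c2nc(=O)c3cc(C(F)(F)F)cc([N+](=O)[O-])c3s2)CC1` gives > 125000 nM in this assay, again a limit.
Compound 3 `Cc1ccc(C(=O)N2CCN(c3nc(=O)c4cc(C(F)(F)F)cc([N+](=O)[O-])c4s3)CC2)cc1` gives > 125000 nM in this assay, also a limit.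

Compound 3 therefore stands only at a limit in this assay, and the same holds for the two compounds beside it, all three sitting at the limit of > 125000 nM in this assay, at which 3 of the 3 values shown sit. Going by the values given here, the one step that joins two measured compounds differing in a single place, a step that the two limits leave unreadable from compound 2 to compound 3, cannot be read in size because both ends are limits.

The piece now turns to compound 4 `O=C(C1CCC1)N1CCN(c2nc(=O)c3cc(C(F)(F)F)cc([N+](=O)[O-])c3s2)CC1`, which has not yet been measured in this assay. Compared with compound 3 the change is cyclobutyl in place of 4-methylphenyl on a carbonyl carbon.

Among the compounds with values here, no measured step gives a readable size that would bear on this change, and every value so far rests at the limit. The expectation for compound 4 is therefore that it, too, will sit at or beyond that limit, with no step beyond the scatter expected from compound 3 to compound 4, a step that the limit leaves unreadable from compound 3 to compound 4. The estimate for compound 4 in this assay is 200000 nM, expected to fall between 100000 nM and 500000 nM.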

Compound 4, half-maximal cytotoxic concentration: > 125000 nM
Compound 4 gave a limit, no number; the forecaster's own chance of this, stated with the estimate: 85%; the middle value is on the limit's open side.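

In this assay compound 4 gives > 125000 nM, which is a limit. The steps joining compound 4 to compound 2 and to compound 3 have limits at both ends, so no new step can be read. The compounds shown leave open whether cyclobutyl, 4-methylphenyl and 2-fluorophenyl on a carbonyl carbon differ at all in this assay, and where any true value lies: the limit of > 125000 nM in this assay, at which 4 of the 4 values shown sit.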